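One Halogen Swap on the Urea Aryl Ring

This account rests on a few compounds, and the source may have more. Where it says the series, first, only, none or still open, it means among the compounds named here.

Compound 1 `CN(C)CCn1cnnc1-c1cc(Oc2ccc(NC(=O)Nc3ccc(Cl)c(C(F)(F)F)c3)cc2F)ccn1` gives 1070 nM in a functional assay on MDA-MB-231 cells (Homo sapiens) for antiproliferative activity, read by MTT assay, with a stated time of 72 h; on this read-out lower numbers stand for stronger inhibition and higher numbers for weaker inhibition.
Compound 2 `CN(C)CCn1cnnc1-c1cc(Oc2ccc(NC(=O)Nc3ccccc3C(F)(F)F)cc2F)ccn1` reaches only the limit > 50000 nM in this assay.
Compound 3 `CN(C)CCn1cnnc1-c1cc(Oc2ccc(NC(=O)Nc3ccc(F)c(F)c3)cc2F)ccn1` likewise reaches only the limit > 50000 nM in this assay.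

Compound 3 therefore stands at the weak end of what has been measured: it shares the limit of > 50000 nM in this assay, at which 2 of the 3 values shown sit, with compound 2, so no number is known for it, only a limit. Compound 4 `CN(C)CCn1cnnc1-c1cc(Oc2ccc(NC(=O)Nc3ccc(F)c(Cl)c3)cc2F)ccn1` differs from compound 3 in one place: chloro in place of fluoro on an aromatic carbon. Going by the values given here, the measured steps that bear on this change both start from compound 1, the only compound with a number. The step of an at least 46-fold higher number from compound 1 to compound 2 (1.66 log units; beyond the scatter) and the step of an at least 46-fold higher number from compound 1 to compound 3 (1.66 log units; beyond the scatter) show that leaving the 4-chloro-3-(trifluoromethyl)phenyl ring costs a great deal. The step that the two limits leave unreadable from compound 2 to compound 3 gives no size. Compound 4 keeps a chloro group in common with compound 1 but lacks the trifluoromethyl, so a partial return toward compound 1 is possible but uncertain. Compound 4 is therefore expected to show an at least 2.5-fold lower number from compound 3 to compound 4 (0.39 log units; beyond the scatter), read against the limit of compound 3. The estimate for compound 4 is 20000 nM, with a range from 3000 nM to 60000 nM.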

Compound 4, half-maximal inhibitory concentration: 8320 nM
Estimate against measurement, compound 4: 2.4-fold (0.38 log units) above, and the stated range covers the measured number.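

In this assay, exchanging one halogen on the urea aryl ring is enough to bring the activity within a measurable range, a step of an at least 6.0-fold lower number from compound 3 to compound 4 (0.77 log units; beyond the scatter), and the comparison with the other weak compound gives an at least 6.0-fold lower number from compound 2 to compound 4 (0.77 log units; beyond the scatter). Compound 2 and compound 3 are each known only by a limit, so both steps give a minimum size and not an exact one: the limit of > 50000 nM in this assay, at which 2 of the 4 values shown sit. Compound 4 still falls short of compound 1, with a 7.8-fold higher number from compound 1 to compound 4 (0.89 log units; beyond the scatter), so the 3-chloro-4-fluorophenyl ring recovers part, but not all, of what is lost on leaving the 4-chloro-3-(trifluoromethyl)phenyl ring.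

Only chloro and fluoro are compared on this carbon, so a bromo, methyl or nitrile group there would be needed to show whether the gain is special to chloro. Compound 1 and compound 4 also differ in two groups on the same ring, which leaves the share of the trifluoromethyl group and the share of the chloro group in that remaining gap unresolved.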